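The compounds below may be only part of what the source reports. "The series", "measured", "known", "first", "only" and "open" are said of these compounds alone.

Measured so far:
- compound 1, `COCC1=CS(=O)(=O)c2ccccc2C1=O`: 99.9%
- compound 2, `COCCOCC1=CS(=O)(=O)c2ccccc2C1=O`: 98.2%
- compound 3, `O=COCC1=CS(=O)(=O)c2ccccc2C1=O`: 91.6%

In a functional assay on the whole organism for inhibition, with Mus musculus as the target, at a dose of 10 mg/kg (a higher number here means more inhibition at the dose given (going by the name of the read-out), a lower number less inhibition), compound 1 gives 99.9%. Of the three numbers this is the highest, but the gaps to the other two are within the usual scatter, so no order among the three compounds is established. The steps are a number 1.7 percentage points lower from compound 1 to compound 2 (within the scatter) and a number 8.3 percentage points lower from compound 1 to compound 3 (within the scatter), and between the other pair a number 6.6 percentage points lower from compound 2 to compound 3 (within the scatter). The numbers of all three measured compounds are level within the scatter at this dose.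

The next compound is compound 4, `O=C1C(CI)=CS(=O)(=O)c2ccccc21`. It differs from compound 1 as follows: iodo in place of methoxy on a saturated chain carbon bound to a double-bonded ring carbon. Within the data shown here, none of the measured steps touches this kind of change: each of them alters what sits on the oxygen of the side chain or lengthens that chain, whereas here the oxygen itself leaves and a halogen enters. The measured steps therefore give no direct guide, and they only show that small changes at this side chain have left the number within the scatter.

Compound 4 is expected to give 92%, with a range from 65% to 100%. That would amount to an expected step of a number 7.9 percentage points lower from compound 1 to compound 4 (within the scatter), which is expected to stay within the scatter.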

Compound 4, a percentage reported as inhibition, in the whole organism at one dose (the size of the read-out at that dose, not a potency): 98%
Estimate against measurement, compound 4: 6 percentage points below; the range from low to high includes it.
By their numbers in this assay, from the lowest: compounds 3, 4, 2 and 1 (each within the scatter of the next).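

Among these compounds, replacing methoxy with iodo removes the oxygen from the side chain altogether, a kind of change the earlier compounds did not cover, and in this assay it gives a number 1.9 percentage points lower from compound 1 to compound 4 (within the scatter) as the step. The same holds against the other two side chains, with a number 0.2 percentage points lower from compound 2 to compound 4 (within the scatter) for iodo in place of 2-methoxyethoxy and a number 6.4 percentage points higher from compound 3 to compound 4 (within the scatter) for iodo in place of formyloxy, so among these four compounds an oxygen on the saturated chain carbon bound to a double-bonded ring carbon is not required for a number at this level. Nothing available here accounts for this result.

All four numbers are level within the scatter at this single dose, so they set no order among the side chains and say nothing about how the compounds would compare at other doses. Going by these compounds, whether a chloro or bromo group, an amine, a carboxylic acid or a longer carbon chain on the same carbon would keep the number at this level remains open, as does the effect of changes elsewhere on the shared core.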